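Swapping Cyclohexyl for Hept-1-en-1-yl

A few compounds are considered here, and "the series" means these few. Any claim that something is new, unique, unknown or untested is made for them only; others in the source may bear on it.

Compound 1 `CCCCCCC/C=C/c1c(C)[nH]c2ccccc2c1=O` gives 4.26
Compound 2 `COc1cc2[nH]c(C)c(C3CCCCC3)c(=O)c2cc1Cl` gives 3.04

Among the compounds with values here, in a physicochemical assay for lipophilicity, at pH 7.4 (a lower number here means a more polar compound, a higher number a more lipophilic compound), compound 2 gives 3.04 and stands lowest of the two compounds measured so far, with compound 1 higher by a gap beyond the usual scatter. Compound 3 `CCCCC/C=C/c1c(C)[nH]c2cc(OC)c(Cl)cc2c1=O` differs from compound 2 in one place, where hept-1-en-1-yl stands in place of cyclohexyl on an aromatic carbon (hept-1-en-1-yl in place of cyclohexyl on an aromatic carbon) and the rest of the structure stays the same.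

Within the data shown here, no two measured compounds differ in only one place, so no direct step is available as a guide. The nearest clue is weak: compound 1 also carries an open chain with a double bond and gives 4.26 in this assay but it differs from compound 2 in other places too. On that basis a rise is expected, and the estimated change is a number 0.66 log units higher from compound 2 to compound 3 (beyond the scatter) in the upward direction, beyond the scatter. Compound 3 is estimated at 3.7 with an expected range from 3.2 to 4.3 until a measurement is available.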

Compound 3, distribution coefficient: 3.57
Estimate against measurement, compound 3: 0.13 log units above; measured number inside the range.
By their numbers in this assay, from the lowest: compound 2; then compound 3; then compound 1.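

Placing hept-1-en-1-yl instead of cyclohexyl on this aromatic carbon gives, in this assay, a number 0.53 log units higher from compound 2 to compound 3 (beyond the scatter), the first direct reading of a change at this position with the rest of the structure held constant. The two groups differ in several ways at once: cyclohexyl has a six-membered non-aromatic ring, while hept-1-en-1-yl has no ring, 1 double bond outside aromatic rings and 7 heavy atoms rather than 6, so this single step shows the combined outcome and cannot assign it to any one of those differences. Nothing measured here explains why the number moves in this direction.

A saturated heptyl chain at the same position would separate the double bond from the opening of the ring, while a phenyl group would show how a flat ring compares with both groups. On these data alone, it also remains open whether a polar end on the chain, such as an amine or a carboxylic acid, would shift the number, and whether this swap gives a similar step on a different core.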